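Cytotoxicity notes on the aminopyrimidine cyclopentanediol series

The source may report more compounds than this note shows. Statements on the series, on what has been measured and on what is new or still open speak of the compounds shown alone.

Measured compounds:
compound 1 `Nc1nc(Cl)c(-c2nc3ccc(Cl)cc3s2)c(N[C@@H]2C[C@H](CO)[C@@H](O)[C@H]2O)n1` — 16000 nM
compound 2 `Cc1nc(N(C)C)nc(N[C@@H]2C[C@H](CO)[C@@H](O)[C@H]2O)c1-c1nc2ccccc2s1` — 18000 nM
compound 3 `CCc1nc(N(C)C)nc(N[C@@H]2C[C@H](CO)[C@@H](O)[C@H]2O)c1-c1nc2ccccc2s1` — > 25000 nM

All three were run in an ADME assay on cells (Homo sapiens) for cytotoxicity, read by polymerase chain reaction, with a stated time of 3 days; a lower number here means that less compound is tolerated, a higher number that more compound is tolerated. Compound 1 gives 16000 nM and compound 2 gives 18000 nM; these two numbers sit within the scatter of each other. Compound 3 gives only a limit, > 25000 nM, so no number is known for it (the limit of > 25000 nM in this assay, at which 1 of the 3 values shown sits). For the measured compounds named here, compound 2 therefore has the higher of the two numbers that are known, with compound 1 close by, and the one further value is a limit.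

Going by the values given here, the single step with a number on both ends is an at least 1.3-fold higher number from compound 2 to compound 3 (0.14 log units; that floor lies within the scatter), whose floor lies within the scatter. It tells little about the change now in question.

Compound 4 `Cc1nc(NCc2nccs2)nc(N[C@@H]2C[C@H](CO)[C@@H](O)[C@H]2O)c1-c1nc2ccccc2s1` differs from compound 2 by ((1,3-thiazol-2-yl)methyl)amino in place of dimethylamino on an aromatic carbon. Among the compounds with values here, no measured step in this set touches the dimethylamino position, so nothing here predicts a shift in this assay beyond the scatter in either direction. Compound 4 is expected to stay near compound 2, meaning a step of no change at the digits printed from compound 2 to compound 4 (within the scatter). The estimate for compound 4 is 18000 nM, between 8000 nM and 40000 nM.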

Compound 4, half-maximal cytotoxic concentration: 23000 nM
The estimate for compound 4 lay 1.3-fold (0.11 log units) below the measured number, and the stated range covers the measured number.
By their numbers in this assay, from the lowest: compounds 1, 2 and 4 (each within the scatter of the next). At a limit, above all of these: compound 3.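

For the compounds shown here, at the dimethylamino position, on the aromatic carbon between two ring nitrogen atoms, this assay gives the first reading of a change: a 1.3-fold higher number from compound 2 to compound 4 (0.11 log units; within the scatter). The entering ((1,3-thiazol-2-yl)methyl)amino group brings more heavy atoms, one five-membered aromatic ring with 2 hetero atoms and 1 hydrogen-bond donor, and the step still stays within the scatter, so this exchange leaves no readable mark on the number. The reading holds for this one exchange, with the methyl group kept on the shared core, and the earlier step from methyl to ethyl gave no information about this position.

Still open, from the compounds shown here alone, is whether a plain primary amine, a carboxylic acid or a longer alkyl chain in this position would give a step beyond the scatter, and whether the ((1,3-thiazol-2-yl)methyl)amino exchange would read the same with the ethyl group of compound 3 in place. Compound 3 stands only as a limit, so the top of the set has no number: the limit of > 25000 nM in this assay, at which 1 of the 4 values shown sits.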